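Solubility at the Hydroxyethyl Amide of a Benzyl Pyridone

This account rests on a few compounds, and the source may have more. Where it says the series, first, only, none or still open, it means among the compounds named here.

Measured compounds:
- compound 1 `CNC(=O)c1cc(C(=O)NCCCC2CNCCO2)cn(Cc2ccccc2)c1=O`: >= 194 ug/mL
- compound 2 `CNC(=O)c1cc(C(=O)NC2CC2)cn(Cc2nccc3[nH]ccc23)c1=O`: 73 ug/mL
- compound 3 `CNC(=O)c1cc(C(=O)NC2CCC2)cn(Cc2cccc(NC)c2)c1=O`: >= 155 ug/mL

In a physicochemical assay for solubility (on this read-out higher numbers stand for higher solubility and lower numbers for lower solubility), compound 1 gives >= 194 ug/mL, which is a limit of the assay and not a number. Compound 3 likewise gives >= 155 ug/mL, also a limit. Compound 2 gives 73 ug/mL. Among these three, compound 1 therefore sits at a limit, (the limit of >= 194 ug/mL in this assay, at which 1 of the 3 values shown sits), rather than at a measured number, and compound 3 sits at the limit of >= 155 ug/mL in this assay, at which 1 of the 3 values shown sits.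

Compound 4 `CNC(=O)c1cc(C(=O)NCCO)cn(Cc2ccccc2)c1=O` differs from compound 1 by one change: hydroxy in place of (morpholin-2-yl)methyl on a saturated chain carbon, two bonds along the chain from an amide-type nitrogen. Within the data shown here, no step between measured compounds resembles this one, so no measured size can be cited. Both compounds carry a hydrogen-bond donor and acceptor on the chain, and compound 4 is expected to remain readily soluble, with a step of an at least 1.0-fold lower number from compound 1 to compound 4 (0.03 log units; that floor lies within the scatter) not beyond the scatter. Compound 4 is estimated at 180 ug/mL, between 60 ug/mL and 260 ug/mL.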

Compound 4, solubility: >= 140 ug/mL
Compound 4: a limit, no number; the forecaster's own chance of this, stated with the estimate: 50%; the middle value is on the limit's open side.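

Compound 1 and compound 4 both stand at limits of the assay rather than at numbers, so no step can be read between them. The compounds shown leave open whether hydroxy in place of (morpholin-2-yl)methyl shifts the read-out at all.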